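Swapping a Pyrrole for Phenyl in an mGluR5 Antagonist Series

This account rests on a few compounds, and the source may have more. Where it says the series, first, only, none or still open, it means among the compounds named here.

Measured so far, in a functional assay on E17 cells for antagonist activity at metabotropic glutamate receptor 5 (Rattus norvegicus), read by fluorescence and calcium flux; on this read-out lower numbers stand for stronger inhibition and higher numbers for weaker inhibition:
- Compound 1, `O=C(Nc1cccc(Cl)c1)O/N=C(\C1CCCCC1)C(Cn1ccnc1)C1CCCCC1`, gives 117 nM; 76 nM (2 entries).
- Compound 2, `O=C(Nc1cccc(Cl)c1)O/N=C(\C1CCCCC1)C(Cc1ccccn1)C1CCCCC1`, gives 65 nM.
- Compound 3, `O=C(Nc1cccc(Cl)c1)O/N=C(\C1CCCCC1)C(Cc1cc[nH]c1)C1CCCCC1`, gives 194 nM.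

Among the compounds with values here, compound 3 stands highest of the single numbers; its nearest neighbour is compound 2, and the step of a 3.0-fold higher number from compound 2 to compound 3 (0.47 log units; beyond the scatter) lies beyond the scatter. Compound 1 has two entries rather than one number, as shown by the several entries of compound 1 in this assay, 117 nM; 76 nM (2 entries).

Compound 4, `O=C(Nc1cccc(Cl)c1)O/N=C(\C1CCCCC1)C(Cc1ccccc1)C1CCCCC1`, has not yet been measured. It differs from compound 3 in one place: phenyl in place of 1H-pyrrol-3-yl on a saturated chain carbon, two bonds along the chain from a carbon with a double bond to nitrogen and a saturated ring carbon.

Within the data shown here, the only measured step at this position, a 3.0-fold higher number from compound 2 to compound 3 (0.47 log units; beyond the scatter), shows that changing the ring here moves the number by a modest amount. Compound 1, with yet another ring at the same place, sits close to compound 2. Three different rings at this position thus give numbers within a narrow band, and the phenyl of compound 4 is expected to fall inside it. Compound 4 is therefore estimated at 90 nM in this assay, with a range from 30 nM to 300 nM, which means an expected step of a 2.2-fold lower number from compound 3 to compound 4 (0.33 log units; beyond the scatter).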

Compound 4, half-maximal inhibitory concentration: 151 nM
The estimate for compound 4 lay 1.7-fold (0.22 log units) below the measured number, and the stated range covers the measured number.
By their numbers in this assay, from the lowest: compound 2; then compounds 4 and 3 (each within the scatter of the next).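

In this assay, the step of a 1.3-fold lower number from compound 3 to compound 4 (0.11 log units; within the scatter) shows that trading the 1H-pyrrol-3-yl ring, with its hydrogen-bond donor, for an all-carbon phenyl ring with no donor leaves a change that cannot be told from assay noise. The pyridin-2-yl ring of compound 2 does stand apart, since the step of a 2.3-fold higher number from compound 2 to compound 4 (0.37 log units; beyond the scatter) is larger than the scatter, as is the earlier step from compound 2 to compound 3. Nothing shown here explains this difference between the rings.

Still open, going by these compounds, is whether this position needs an aromatic ring at all, or whether a plain longer chain could replace it. A chain ending in an amine or a carboxylic acid, or a phenyl ring carrying a fluorine atom, could also shift the number in either direction.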